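Series notes: sulfonylpiperidine amides, a sulfonyl substituent swap

A few compounds are considered here, and "the series" means these few. Any claim that something is new, unique, unknown or untested is made for them only; others in the source may bear on it.

Measured so far:
compound 1, `CCOC(=O)[C@@H]1CCCN(S(=O)(=O)c2ccc(S(=O)(=O)N3CCOCC3)cc2)C1`: 4100 nM
compound 2, `CCN(CC)S(=O)(=O)c1ccc(S(=O)(=O)N2CCC[C@@H](C(=O)N3CCC(c4nc(C(C)C)no4)CC3)C2)cc1`: 30 nM

In a functional assay on MIA PaCa-2 cells (Homo sapiens) for inhibition, read by MTT assay, with a stated time of 3 days (on this read-out higher numbers stand for weaker inhibition and lower numbers for stronger inhibition), compound 2 gives 30 nM and compound 1 gives 4100 nM. Compound 2 therefore holds the lower of the two numbers, and the gap to compound 1 lies well beyond the scatter of this assay. The two differ in several places at once, so the gap cannot be assigned to any single change.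

The next compound is compound 3, `CC(C)c1noc(C2CCN(C(=O)[C@@H]3CCCN(S(=O)(=O)c4ccc(S(=O)(=O)C(C)C)cc4)C3)CC2)n1`. It keeps the amide side of compound 2 intact and changes only the distal sulfonyl group: isopropyl in place of diethylamino on a sulfonyl sulfur. Among the measured compounds shown here, no measured pair varies this position alone, so the size of the step rests on no direct precedent. The piperidine amide, which is common to compound 2 and compound 3, is retained. A step of modest size is expected in this assay, within the scatter or slightly toward weaker inhibition, and the expected step from compound 2 to compound 3 is a 2.0-fold higher number from compound 2 to compound 3 (0.30 log units; within the scatter). Compound 3 is estimated at 60 nM in this assay, with a likely range from 15 nM to 300 nM.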

Compound 3, half-maximal inhibitory concentration: 20 nM
Compound 3: middle estimate off by 3.0-fold (0.48 log units), on the high side, and the stated range covers the measured number.
By their numbers in this assay, from the lowest: compounds 3 and 2 (each within the scatter of the next); then compound 1.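

In this assay, among the compounds shown here, replacing diethylamino with isopropyl on a sulfonyl sulfur gives a 1.5-fold lower number from compound 2 to compound 3 (0.18 log units; within the scatter), so this pair provides the first reading of this position alone, and the two compounds cannot be told apart on this read-out. The same difference, cut one bond further out, is diethylsulfamoyl to isopropylsulfonyl: the substituent goes from 5 heavy atoms to 3 heavy atoms and loses its nitrogen, and the number in this assay stays within the scatter across that single exchange. No independent data offer a reason for this outcome.

Going by these compounds, this one pair leaves open how far the position tolerates other groups, since neither substituent carries a ring or a hydrogen-bond donor, and whether a phenyl ring, a primary amine or a carboxylic acid on the sulfonyl sulfur would hold the number in this assay remains unknown. Compound 1 carries a different sulfonyl substituent but also differs from compound 2 and compound 3 elsewhere, so it cannot settle this question.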